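This account rests on a few compounds, and the source may have more. Where it says the series, first, only, none or still open, it means among the compounds named here.

Compound 1 `Cc1ccccc1N1CCN(C[C@H](C)Nc2nc(C(F)(F)F)nc3ccccc23)CC1`: 730 nM
Compound 2 `Cc1ccc(S(=O)(=O)N2CCN(C[C@H](C)Nc3ncnc4c(C)csc34)CC2)cc1`: 170 nM
Compound 3 `Cc1noc(-c2ccccc2)c1NC(=O)OC(C)c1ccccc1`: > 50000 nM

In a functional assay on RH7777 cells for antagonist activity at lysophosphatidic acid receptor 2 (Homo sapiens), read by calcium flux (a lower number here means a stronger inhibitor, a higher number a weaker inhibitor), compound 2 gives 170 nM, the lowest of the two numbers recorded. Compound 1 gives 730 nM, a higher number that lies beyond the scatter. The value of compound 3, > 50000 nM, is a limit of the assay rather than a number (the limit of > 50000 nM in this assay, at which 1 of the 3 values shown sits).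

Compound 4 `CCCCS(=O)(=O)N1CCN(C[C@H](C)Nc2ncnc3c(C)csc23)CC1` differs from compound 2 in one place: butyl in place of 4-methylphenyl on a sulfonyl sulfur. Within the data shown here, no measured pair covers a change of this kind, so its size cannot be read from the data. The author expects the step of a 1.9-fold higher number from compound 2 to compound 4 (0.27 log units; within the scatter) to be small, toward a higher number, and possibly not beyond the scatter. Compound 4 is therefore estimated at 320 nM, within 90 nM to 1200 nM.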

Compound 4, half-maximal inhibitory concentration: 6610 nM
Compound 4: middle estimate off by 21-fold (1.32 log units), on the low side; measured number outside the range, above it.
By their numbers in this assay, from the lowest: compound 2; then compound 1; then compound 4. At a limit, above all of these: compound 3.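

On the sulfonyl sulfur, the group is far from interchangeable: in this assay, butyl in place of 4-methylphenyl brings a 39-fold higher number from compound 2 to compound 4 (1.59 log units; beyond the scatter). Among these compounds, this is the first measured pair at this position, and the side that keeps the six-membered aromatic ring has the lower number. Nothing measured here accounts for the size of this step. Going by these compounds, it remains open whether the loss follows from removing the ring or its methyl group, and whether an unsubstituted phenyl, a cyclohexyl or a longer chain on the sulfonyl sulfur would restore the lower number.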